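This account rests on a few compounds, and the source may have more. Where it says the series, first, only, none or still open, it means among the compounds named here.

Measured compounds in this series:

compound 1 `Cc1cccc(-n2nncc2CN2C(=O)C3(C(C#N)=C(N)Oc4c(N)cc5nc6ccccc6nc5c43)c3ccccc32)c1` — > 50000 nM
compound 2 `N#CC1=C(N)Oc2c(N)cc3nc4ccccc4nc3c2C12C(=O)N(Cc1cnnn1-c1ccc(Cl)cc1)c1ccccc12` — > 50000 nM
compound 3 `N#CC1=C(N)Oc2c(N)cc3nc4ccccc4nc3c2C12C(=O)N(Cc1cnnn1-c1ccccc1Cl)c1ccccc12` — 34400 nM

In a functional assay on MCF7 cells (Homo sapiens) for antiproliferative activity, read by MTT assay, with a stated time of 48 h (on this read-out lower numbers stand for stronger inhibition and higher numbers for weaker inhibition), compound 1 reaches only a limit of the assay, > 50000 nM. Compound 2 likewise returns a limit, > 50000 nM. Within the data shown here, compound 3 is the one compound that yields a number, 34400 nM. Among the measured compounds shown here, two of the three values thus rest on the limit (the limit of > 50000 nM in this assay, at which 2 of the 3 values shown sit), and the single number stands close to it. The step from the 3-methylphenyl compound to the 2-chlorophenyl compound, an at least 1.4-fold lower number from compound 1 to compound 3 (0.16 log units; that floor lies within the scatter), is a floor that lies within the scatter; the same holds for an at least 1.4-fold lower number from compound 2 to compound 3 (0.16 log units; that floor lies within the scatter). The step that the two limits leave unreadable from compound 1 to compound 2 cannot be read at all, as both ends are limits.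

Compound 4 `N#CC1=C(N)Oc2c(N)cc3nc4ccccc4nc3c2C12C(=O)N(Cc1cnnn1-c1cccc(Br)c1)c1ccccc12` carries 3-bromophenyl in place of 2-chlorophenyl on an aromatic nitrogen. For the measured compounds named here, the steps that bear on it are an at least 1.4-fold lower number from compound 1 to compound 3 (0.16 log units; that floor lies within the scatter) and an at least 1.4-fold lower number from compound 2 to compound 3 (0.16 log units; that floor lies within the scatter), both floors inside the scatter, so no direction beyond the scatter can be drawn from them. Compound 1, which bears 3-methylphenyl, sits at the limit, and compound 2, with 4-chlorophenyl, sits there too. For compound 4 the expectation is therefore a value at or near the limit, with the step of a 1.5-fold higher number from compound 3 to compound 4 (0.16 log units; within the scatter) expected to be small. Compound 4 is estimated at 50000 nM, within 20000 nM to 120000 nM.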

Compound 4, half-maximal inhibitory concentration: > 50000 nM
Compound 4: only a limit was reported; the forecaster's own chance of this, stated with the estimate: 60%; the middle value lies on the limit itself.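

In this assay compound 4 returns only a limit, > 50000 nM. Among these compounds, replacing 2-chlorophenyl with 3-bromophenyl on the aromatic nitrogen gives an at least 1.4-fold higher number from compound 3 to compound 4 (0.16 log units; that floor lies within the scatter), a floor inside the scatter, so this change shows no direction, and compound 3 remains the only compound with a number. The steps to compound 4 from compound 1 and from compound 2 cannot be read, but the series now holds a bromo-substituted phenyl on this nitrogen alongside the methyl- and chloro-substituted phenyl groups of compound 1 and compound 2, and all three return a limit rather than a number: the limit of > 50000 nM in this assay, at which 3 of the 4 values shown sit.

Whether any group at this position can bring a value in this assay clearly away from the limit stays open, as the compounds shown cover only methyl, chloro and bromo on the phenyl ring. As far as these compounds go, how an amine or a carboxylic acid on that ring, or a longer chain in place of the phenyl ring, would read remains unknown from these compounds.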